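The compounds below may be only part of what the source reports. "The series", "measured", "known", "first", "only" and "open" are said of these compounds alone.

Compound 1, with the structure `C=C1CC[C@H]2C(C)(C)CCC[C@]2(C)[C@H]1CC/C(C)=C/Cc1c(O)cc(O)c2c(=O)c(O)c(-c3ccc(O)cc3)oc12`, and compound 3, with the structure `C=C1CC[C@H]2C(C)(C)CCC[C@]2(C)[C@H]1CC/C(C)=C/COc1cc(O)c2c(=O)c(O)c(-c3ccc(O)cc3)oc2c1`, are built from the same atoms joined differently; the difference between the two cores is not broken down here. Compound 2, `C=C1CC[C@H]2C(C)(C)CCC[C@]2(C)[C@H]1CC/C(C)=C/COc1cc(O)c2c(=O)c(O)c(-c3ccc(OC)cc3)oc2c1`, carries the core of compound 3 with one change, and compound 4, `C=C1CC[C@H]2C(C)(C)CCC[C@]2(C)[C@H]1CC/C(C)=C/Cc1c(O)cc(O)c2c(=O)c(O)c(-c3ccc(OC)cc3)oc12`, carries the core of compound 1 with that same change, namely (methyl in place of hydrogen on an oxygen on an aromatic ring). In a functional assay on HT-29 cells (Homo sapiens) for cytotoxicity, read by XTT assay, with a stated time of 72 h (on this read-out lower numbers stand for stronger inhibition and higher numbers for weaker inhibition), compound 1 gives 29000 nM. Compound 3 reaches only a limit of this assay, > 100000 nM. Compound 2 likewise reaches only a limit of this assay, > 100000 nM. The change from compound 3 to compound 2, (methyl in place of hydrogen on an oxygen on an aromatic ring), therefore gives a step that the two limits leave unreadable from compound 3 to compound 2, because of the limit of > 100000 nM in this assay, at which 2 of the 3 values shown sit. So the size of this change is not readable from the measured pair, and only the number for compound 1 gives a starting point. For compound 4 the same change is expected to leave the value near that of compound 1, with an estimated step of a 1.4-fold higher number from compound 1 to compound 4 (0.14 log units; within the scatter). Compound 4 is thus estimated at 40000 nM, expected to lie between 12000 nM and 100000 nM.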

Compound 4, half-maximal inhibitory concentration: > 100000 nM
Compound 4: only a limit was reported; the forecaster's own chance of this, stated with the estimate: 30%; middle value at least 2.5-fold (0.39 log units) from the limit.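

In this assay, replacing 4-hydroxyphenyl with 4-methoxyphenyl on the core of compound 1 gives an at least 3.4-fold higher number from compound 1 to compound 4 (0.53 log units; beyond the scatter), so on this core the change weakens the effect by more than the usual scatter. Compound 4 reaches only a limit of this assay, > 100000 nM. This does not show that the change has the same size on both cores, because the step on the core of compound 3 cannot be read and the step on the core of compound 1 has no upper end: the limit of > 100000 nM in this assay, at which 3 of the 4 values shown sit.

The compounds shown leave open whether an ethyl group or a longer chain on that oxygen would behave like the methyl group, and whether an amine in place of the hydroxy would keep the effect. Within the data shown here, they also leave open whether any such group on the core of compound 1 could bring the number below that of compound 1, 29000 nM, the only value here that is not a limit.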